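The compounds below may be only part of what the source reports. "The series", "measured", "known", "first", "only" and "open" are said of these compounds alone.

Measured compounds in an ADME assay on the whole organism with Oryza sativa as the target, tested at 10 uM; a lower number here means a stronger effect, a higher number a weaker effect of the compound at the concentration tested:
compound 1, `CCc1ccccc1NC(=O)N[C@H](C)c1ccccc1`: 92%
compound 2, `CCc1ccccc1NC(=O)N[C@@H](C)c1ccccc1`: 95%
compound 3, `CCOC(=O)c1ccc(NC(=O)N[C@@H](C)c2ccccc2)cc1`: 92%

In this assay compound 1 stands level with compound 3 at the digits shown, and together the two are the lowest of the three numbers. The nearest number to compound 1 is that of compound 3, with no change at the digits shown and within the scatter; the furthest is that of compound 2. For the measured compounds named here, the only measured step that changes a single feature is a number 3 percentage points higher from compound 1 to compound 2 (within the scatter), a step within the scatter, and it rests on (the fact that compounds 1 and 2 differ only in the configuration as drawn).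

Compound 4, `CC(=O)c1ccccc1NC(=O)N[C@H](C)c1ccccc1`, is not yet measured. Against compound 1 it differs by acetyl in place of ethyl on an aromatic carbon. Going by the values given here, no measured step concerns a group on the aromatic ring of the shared core: the single measured step touches configuration only and stays within the scatter, and compound 3 carries its change on a different position and gives the same number as compound 1. Nothing measured therefore points to a step beyond the scatter in either direction, and the expectation is that no change at the digits printed from compound 1 to compound 4 (within the scatter) stays within the scatter. Compound 4 is estimated at 92%, with an expected range from 80% to 100%.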

Compound 4, a percentage reported as activity, at one concentration (the size of the read-out at that concentration, not a potency): 89%
Compound 4: the middle estimate sits 3 percentage points above what was measured; the range from low to high includes it.
By their numbers in this assay, from the lowest: compounds 4, 1, 3 and 2 (each within the scatter of the next).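

In this assay, for the compounds shown here, acetyl in place of ethyl on an aromatic carbon ortho to a large group gives a number 3 percentage points lower from compound 1 to compound 4 (within the scatter), the first measured step at this position of the shared core. The exchange brings in an oxygen, a double bond outside aromatic rings and a hydrogen-bond acceptor, yet the read-out at the tested concentration does not separate acetyl from ethyl here, so this position accepts this particular change without a step beyond the scatter. No available evidence bears on the reason for this reading.

The compounds shown leave open whether any group on this aromatic carbon can move the number beyond the scatter, for instance an amine, a carboxylic acid or a longer chain in place of ethyl. Going by these compounds alone, they also leave open whether the stereocentre at the saturated chain carbon counts for anything with acetyl in place, since the only step on configuration concerns the ethyl compounds and, like the acetyl step, stays within the scatter.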